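Hexyl on the phenyl ring of a trimethoxyphenyl oxadiazole

The source may hold more compounds than are shown below. What is called first, only, known or untested is meant among the compounds shown, and "the series" means these compounds.

These notes follow the shared core of compound 1 `COc1cc(-c2noc(-c3ccccc3)n2)cc(OC)c1OC` through a functional assay on cells (Splenocyte, Mus musculus, strain BALB/c) for inhibition, read by scintillation counting and thymidine incorporation, with stated times of 48 h and 8 h; on this read-out lower numbers stand for stronger inhibition and higher numbers for weaker inhibition. Compound 1 gives only a limit in this assay, > 50000 nM, so no number stands for it. Compound 2 `COc1cc(-c2noc(-c3cc(OC)c(OC)c(OC)c3)n2)cc(OC)c1OC` also gives only a limit, > 50000 nM. Of the three values at hand, (the limit of > 50000 nM in this assay, at which 2 of the 3 values shown sit), and only compound 3 `COc1cc(-c2noc(C34CCC(N)(CC3)CC4)n2)cc(OC)c1OC` returns a number, 4100 nM in this assay. Among the compounds with values here, compound 1 therefore stands at the weak end of what has been measured, without a value of its own, and no step between measured compounds is available to size the change in question.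

Compound 4 `CCCCCCc1ccc(-c2nc(-c3cc(OC)c(OC)c(OC)c3)no2)cc1` is yet to be measured. It differs from compound 1 by hexyl in place of hydrogen on an aromatic carbon. Since compound 1 and compound 2 both sit at the limit, and only compound 3, with its different group on the core, gives a number, the shown values offer no measured guide to what a hexyl chain does here.

The step is expected to be an at least 1.6-fold lower number from compound 1 to compound 4 (0.22 log units; that floor lies within the scatter), toward a weak number or another limit. Compound 4 is expected to give about 30000 nM in this assay, within 5000 nM to 100000 nM.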

Compound 4, half-maximal inhibitory concentration: 22900 nM
For compound 4 the middle estimate is 1.3-fold (0.12 log units) above the measured one; measured number inside the range.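

In this assay, hexyl in place of hydrogen on an aromatic carbon, para to a large group, gives an at least 2.1-fold lower number from compound 1 to compound 4 (0.33 log units; beyond the scatter). Within the data shown here, this is the first sign that this position can change the read-out: compound 4 gives a number, 22900 nM, though a weak one. The step has only a floor and no exact size, because compound 1 stands at a limit and has no number of its own: the limit of > 50000 nM in this assay, at which 2 of the 4 values shown sit.

The compounds shown give one chain at one place, so they do not tell whether the effect depends on chain length or on the presence of a chain at all, and a shorter chain such as propyl or a longer chain such as decyl on the same carbon would bear on that. They also leave open whether an amine or a carboxylic acid at this position would move the read-out in the same direction, and nothing here gives a cause for the step.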